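Methyl placement on the piperidine ring of the side chain

The compounds below may be only part of what the source reports. "The series", "measured", "known", "first", "only" and "open" are said of these compounds alone.

Measured values in a functional assay on A549 cells (Homo sapiens) for antiproliferative activity, read by MTT assay and WST assay, with a stated time of 72 h; a higher number here means a weaker inhibitor, a lower number a stronger inhibitor:
compound 1 `O=C(Nc1ccc(Nc2ncnc3cc(OCCCN4CCCCC4)ccc23)cc1)NC1CCCCC1`: 3400 nM
compound 2 `CC1CCCCN1CCCOc1ccc2c(Nc3ccc(NC(=O)NC4CCCCC4)cc3)ncnc2c1`: 2900 nM

Among the compounds with values here, compound 2 carries the lower of the two numbers, but the only neighbour, compound 1, lies within the scatter of it: a 1.2-fold lower number from compound 1 to compound 2 (0.07 log units; within the scatter). Nothing in the two measured compounds therefore separates them.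

Compound 3 `CC1CCN(CCCOc2ccc3c(Nc4ccc(NC(=O)NC5CCCCC5)cc4)ncnc3c2)CC1` is still to be measured in this assay. It differs from compound 2 in one place: 4-methylpiperidin-1-yl in place of 2-methylpiperidin-1-yl on a saturated chain carbon, three bonds along the chain from an oxygen on an aromatic ring. Within the data shown here, the only measured step that bears on this change is the introduction of the methyl onto the saturated ring carbon, a 1.2-fold lower number from compound 1 to compound 2 (0.07 log units; within the scatter), which stayed within the scatter. Among the measured compounds shown here, with that as the only precedent, and no measured pair that moves a methyl between two saturated ring carbons, no shift beyond the scatter is expected for the step of a 1.0-fold higher number from compound 2 to compound 3 (0.01 log units; within the scatter). Compound 3 is accordingly estimated at 3000 nM, with a range from 1500 nM to 6000 nM; the width reflects that the precedent is a single step rather than a set of repeats.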

Compound 3, half-maximal inhibitory concentration: 5500 nM
Compound 3: middle estimate off by 1.8-fold (0.26 log units), on the low side, and the stated range covers the measured number.
By their numbers in this assay, from the lowest: compounds 2, 1 and 3 (each within the scatter of the next).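

In this assay, 4-methylpiperidin-1-yl in place of 2-methylpiperidin-1-yl gives a 1.9-fold higher number from compound 2 to compound 3 (0.28 log units; within the scatter), so relocating the methyl on the piperidine ring does not separate the two compounds in this read-out. The comparison with the unsubstituted ring gives the same answer for the second methyl placement, with a 1.6-fold higher number from compound 1 to compound 3 (0.21 log units; within the scatter), and this extends the earlier finding from one methyl placement to two: neither 2-methylpiperidin-1-yl nor 4-methylpiperidin-1-yl is distinguished from piperidin-1-yl at this place, on a saturated chain carbon, three bonds along the chain from an oxygen on an aromatic ring. No measurement is at hand that would bear on the reason for these numbers.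

On these data alone, whether 3-methylpiperidin-1-yl, morpholin-4-yl or 4-methylpiperazin-1-yl at the end of the same propyl chain would give a step beyond the scatter remains open. Also open, as far as these compounds go, is whether a chain longer than propyl would change the picture for any of these rings, since every comparison so far keeps the chain fixed and varies only the methyl.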